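This account rests on a few compounds, and the source may have more. Where it says the series, first, only, none or still open, it means among the compounds named here.

Measured compounds:
compound 1 `CCOC(=O)NC(c1ccccc1)c1ccc(Cl)cc1`: > 250000 nM
compound 2 `COc1ccc(C(=NNC(=O)NNC(=O)NCCCC(C)Nc2cc(OC)cc3cccnc23)c2ccc(OC)cc2)cc1`: 50000 nM
compound 3 `COc1cc(NC(C)CCCNC(=O)NNC(=O)Nc2ccc(Cl)c(C(F)(F)F)c2)c2ncccc2c1`: 17000 nM

In a functional assay on HeLa cells (Homo sapiens) for inhibition, read by MTT assay, with a stated time of 4 days (a lower number here means a stronger inhibitor, a higher number a weaker inhibitor), compound 1 gives > 250000 nM, which is a limit of the assay and not a number. Compound 1 thus sits at the limit of > 250000 nM in this assay, at which 1 of the 3 values shown sits. Compound 2 gives 50000 nM and compound 3 gives 17000 nM, both real numbers. The untested compound 4 `NNC(=O)NC(c1ccccc1)c1ccc(Cl)cc1` keeps the core of compound 1 and differs from it in one place: aminoamino in place of ethoxy on a carbonyl carbon. For the measured compounds named here, no measured pair shows this change, so its effect is unknown; a small shift toward stronger inhibition, or none beyond the scatter, seems the likeliest outcome. The expected step is an at least 1.6-fold lower number from compound 1 to compound 4 (0.22 log units; that floor lies within the scatter). Compound 4 is estimated at 150000 nM, within a range of 30000 nM to 600000 nM.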

Compound 4, half-maximal inhibitory concentration: 182000 nM
Compound 4: the middle estimate sits 1.2-fold (0.08 log units) below what was measured; low and high end bracket the measured number.
By their numbers in this assay, from the lowest: compound 3; then compound 2; then compound 4. At a limit, above all of these: compound 1.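

With aminoamino in place of ethoxy on a carbonyl carbon, the shared core gives a real number in this assay rather than only a limit, and the change reads as an at least 1.3-fold lower number from compound 1 to compound 4 (0.13 log units; that floor lies within the scatter). This is a floor and not a measured size, so the change may be small or much larger. The true size stays hidden because compound 1 gives a limit and not a number: the limit of > 250000 nM in this assay, at which 1 of the 4 values shown sits.

The compounds shown leave open how a simple amine or a longer chain at this carbonyl carbon would compare. As far as these compounds go, whether a methoxy group would behave like ethoxy also remains open.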